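The source may hold more compounds than are shown below. What is called first, only, known or untested is meant among the compounds shown, and "the series" means these compounds.

Compound 2, with the structure `CCCCN(CCC)c1nc(C)nc2c(-c3c(C)cc(N(C)C)nc3C)c(C)nn12`, gives 12.8 nM in an assay on cell membranes for displacement of a labelled ligand from corticotropin-releasing factor receptor 1 (Rattus norvegicus) (a higher number here means a weaker inhibitor, a lower number a stronger inhibitor), the highest of the three numbers recorded there. Compound 1, with the structure `CCCCN(C)c1nc(C)nc2c(-c3ccc(OC)nc3C)c(C)nn12`, gives 8.1 nM, within the scatter of compound 2. Compound 3, with the structure `CCCN(CC1CC1)c1nc(C)nc2c(-c3ccc(OC)nc3C)c(C)nn12`, gives 1.6 nM, beyond the scatter from compound 2, and the step of a 5.1-fold lower number from compound 1 to compound 3 (0.70 log units; beyond the scatter) shows that the amino group on this aromatic carbon can shift the number by a modest amount.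

Compound 4, with the structure `COCCNc1nc(C)nc2c(-c3c(C)cc(N(C)C)nc3C)c(C)nn12`, carries the change ((2-methoxyethyl)amino in place of butyl(propyl)amino on an aromatic carbon). Among the compounds with values here, no measured step matches this change; the only step that bears on it, a 5.1-fold lower number from compound 1 to compound 3 (0.70 log units; beyond the scatter), concerns the same position and was modest. As the entering group is shorter and brings a hydrogen-bond donor, a higher number is expected, estimated as a 6.3-fold higher number from compound 2 to compound 4 (0.80 log units; beyond the scatter). Compound 4 is therefore expected to give about 80 nM in this assay, plausibly between 20 nM and 400 nM.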

Compound 4, half-maximal inhibitory concentration: > 10000 nM
Compound 4 was reported as a limit; the forecaster's own chance of this, stated with the estimate: 5%; middle value at least 120-fold (2.09 log units) away from the limit.
By their numbers in this assay, from the lowest: compound 3; then compounds 1 and 2 (each within the scatter of the next). At a limit, above all of these: compound 4.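

On the aromatic carbon between two ring nitrogen atoms, (2-methoxyethyl)amino in place of butyl(propyl)amino gives an at least 780-fold higher number from compound 2 to compound 4 (2.89 log units; beyond the scatter) in this assay. Within the data shown here, the earlier step at this position, a 5.1-fold lower number from compound 1 to compound 3 (0.70 log units; beyond the scatter), was modest, so the compounds before this one showed only that the amino group can tune the number, not that one change there can take the number out of the measurable range. The result for compound 4 is a limit and not a number: the limit of > 10000 nM in this assay, at which 1 of the 4 values shown sits.

The compounds shown leave open which part of the change carries this large step, as the chain, the oxygen and the hydrogen on the nitrogen all change together. Going by these compounds, a butylamino group, or a bis(2-methoxyethyl)amino group, would separate these, and the true size of the step stays unknown beyond its limit.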